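This account rests on a few compounds, and the source may have more. Where it says the series, first, only, none or still open, it means among the compounds named here.

Measured in a functional assay on K562 cells (Homo sapiens), read by MTT assay, with a stated time of 72 h; a higher number here means a weaker inhibitor, a lower number a stronger inhibitor:
Compound 1 `COc1ncnc2c1c(-c1cc3ccccc3o1)cn2[C@@H]1O[C@H](CO)[C@@H](O)[C@H]1O`: 20900 nM
Compound 2 `CSc1ncnc2c1c(-c1ccsc1)cn2[C@@H]1O[C@H](CO)[C@@H](O)[C@H]1O`: 450 nM
Compound 3 `C#Cc1cn([C@@H]2O[C@H](CO)[C@@H](O)[C@H]2O)c2ncnc(SC)c12`: 30 nM

Among these three, compound 3 has the lowest number, at 30 nM. The next compound to consider is compound 4 `C#Cc1cn([C@@H]2O[C@H](CO)[C@@H](O)[C@H]2O)c2ncnc(NC)c12`, which keeps the ethynyl group of compound 3 and carries methylamino in place of methylsulfanyl on an aromatic carbon.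

Among the measured compounds shown here, the one measured step, a 15-fold lower number from compound 2 to compound 3 (1.18 log units; beyond the scatter), is large, but it concerns a different change, ethynyl in place of thiophen-3-yl. Compound 4 retains the ethynyl group from that step, so the step supports a low number only indirectly. For the measured compounds named here, no measured pair exchanges methylsulfanyl for methylamino, so the size of this change in this assay has no direct precedent. Compound 3, at 30 nM, already sits at the low end of the series, so a moderate rise seems more likely than a further fall, though a result within the scatter cannot be excluded. The expected change is a 6.7-fold higher number from compound 3 to compound 4 (0.82 log units; beyond the scatter). For compound 4 the estimated value is 200 nM, with an expected range from 30 nM to 1500 nM.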

Compound 4, half-maximal inhibitory concentration: > 20000 nM
Compound 4: only a limit was reported; the forecaster's own chance of this, stated with the estimate: 5%; middle value at least 100-fold (2.00 log units) from the limit.
By their numbers in this assay, from the lowest: compound 3; then compound 2; then compound 1.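

In this assay, exchanging methylsulfanyl for methylamino on the aromatic carbon next to the ring nitrogen, with the ethynyl group kept, gives an at least 660-fold higher number from compound 3 to compound 4 (2.82 log units; beyond the scatter), so this position responds strongly to the change, which brings in a hydrogen-bond donor that methylsulfanyl lacks. The result for compound 4 is a limit of the assay and not a number: the limit of > 20000 nM in this assay, at which 1 of the 4 values shown sits. The earlier step, a 15-fold lower number from compound 2 to compound 3 (1.18 log units; beyond the scatter), showed only what the ethynyl group did with methylsulfanyl in place, whereas this step shows that keeping the ethynyl group does not by itself hold the number low.

What a free amino group, dimethylamino or ethylsulfanyl would do at this place with the ethynyl group kept remains open, so the compounds shown do not tell whether methylsulfanyl is special or methylamino alone is poorly placed there. Also open, on these data alone, is whether a propynyl group or a nitrile could stand in for the ethynyl group alongside methylsulfanyl, as in compound 3.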